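This account rests on a few compounds, and the source may have more. Where it says the series, first, only, none or still open, it means among the compounds named here.

Of the compounds shown here, three built on one shared core have been tested in an ADME assay on MT2 cells (Homo sapiens) for cytotoxicity, read by XTT assay, with a stated time of 4 days; on this read-out higher numbers stand for lower toxicity in this test and lower numbers for higher toxicity in this test. Compound 1, `Cc1ccc(-c2c3c(nc(C)c2[C@H](OC(C)(C)C)C(=O)O)CCN(c2ccccc2)C3)cc1`, gives > 40000 nM there, which is a limit of the test and not a measured number. Compound 2, `CC(=O)N1CCc2nc(C)c(C(OC(C)(C)C)C(=O)O)c(-c3ccc(C)cc3)c2C1`, likewise reaches only a limit in this assay, > 40000 nM. Compound 3, `Cc1ccc(-c2c3c(nc(C)c2[C@H](OC(C)(C)C)C(=O)O)CCN(CCCc2ccccc2)C3)cc1`, also stops at a limit in this assay, > 40000 nM. Among the measured compounds shown here, the one step that joins two of these measured compounds in one place, a step that the two limits leave unreadable from compound 1 to compound 3, therefore has no readable size. Compound 2 thus stands where the other two stand: all of the values shown sit at the limit of > 40000 nM in this assay, at which 3 of the 3 values shown sit.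

Compound 4, `COC(=O)N1CCc2nc(C)c(C(OC(C)(C)C)C(=O)O)c(-c3ccc(C)cc3)c2C1`, differs from compound 2 in a single place: methoxy in place of methyl on a carbonyl carbon. Read one bond further out, the change is acetyl to methoxycarbonyl.

For the measured compounds named here, no measured step bears directly on this exchange, and the single step available, from compound 1 to compound 3, cannot be read in size. Because every value shown sits at the limit of > 40000 nM in this assay, at which 3 of the 3 values shown sit, no step beyond the usual scatter is expected in either direction. The step that the limit leaves unreadable from compound 2 to compound 4 is therefore expected to be essentially nil. Compound 4 is estimated at 60000 nM, within a range from 30000 nM to 200000 nM, and is most likely to be reported once more only as a limit.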

Compound 4, half-maximal cytotoxic concentration: > 40000 nM
Compound 4 gave a limit, no number; the forecaster's own chance of this, stated with the estimate: 85%; the middle value is on the limit's open side.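

In this assay compound 2 and compound 4 both stop at a limit of the test, so no new step can be read between them, and the same holds across the whole set: (the limit of > 40000 nM in this assay, at which 4 of the 4 values shown sit).

The compounds shown leave open the concentration at which any of them would become toxic to these cells, and so whether methoxy in place of methyl on a carbonyl carbon changes toxicity in this test at all.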